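Anilide series: tolerance in macrophage cytotoxicity

The source may hold more compounds than are shown below. What is called first, only, known or untested is meant among the compounds shown, and "the series" means these compounds.

Compound 2 `COc1ccccc1C(=O)Nc1ccc(I)cc1F` gives, in an ADME assay on RAW264.7 cells (Mus musculus) for cytotoxicity, read by MTT assay, with a stated time of 24 h (a higher number here means that more compound is tolerated, a lower number that less compound is tolerated), only a limit of the assay, > 40000 nM. Compound 1 `O=C(Nc1ccc(F)cc1F)c1ccccc1OCc1ccc(F)cc1F` likewise reaches only a limit, > 40000 nM. Both readings therefore sit at the limit of > 40000 nM in this assay, at which 2 of the 2 values shown sit, so compound 2 stands at the top of what the numbers shown can tell. Compound 3 `O=C(Nc1ccc(I)cc1F)c1ccccc1OCc1ccc(F)cc1F` differs from compound 2 by 2,4-difluorophenyl in place of hydrogen on a saturated chain carbon bound to an oxygen on an aromatic ring. Within the data shown here, no measured step covers this change, so no shift beyond the scatter is expected in this assay from compound 2 to compound 3 (a step that the limit leaves unreadable from compound 2 to compound 3). For compound 3 the expected value in this assay is 45000 nM, within 20000 nM to 100000 nM, most likely again reported only as a limit.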

Compound 3, half-maximal cytotoxic concentration: 32600 nM
Compound 3: middle estimate off by 1.4-fold (0.14 log units), on the high side, and the stated range covers the measured number.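

Among these compounds, compound 3 is the first compound to give a number rather than a limit in this assay, so a cytotoxic concentration can be read within this set. With 2,4-difluorophenyl on the saturated chain carbon bound to an oxygen on an aromatic ring, the result is an at least 1.2-fold lower number from compound 2 to compound 3 (0.08 log units; that floor lies within the scatter), and iodo in place of fluoro on an aromatic carbon gives an at least 1.2-fold lower number from compound 1 to compound 3 (0.08 log units; that floor lies within the scatter). Both steps are floors only, so neither change can be sized: the limit of > 40000 nM in this assay, at which 2 of the 3 values shown sit.

As far as these compounds go, the true sizes of both steps remain open. Also open, from the compounds shown here alone, is how an amine or a carboxylic acid on that chain carbon would read.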